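Cyclic urea series: methylsulfanyl replaced by thiophene on the aryl ring

The source may report more compounds than this note shows. Statements on the series, on what has been measured and on what is new or still open speak of the compounds shown alone.

The series shares a cyclic urea core carrying an aromatic group. Compound 1 `CSc1cccc(N2CCNC(=O)N2)c1` and compound 2 `O=C1NCCN(c2ccccn2)N1` have been measured in an assay on RBL-1 cells for inhibition of Polyunsaturated fatty acid 5-lipoxygenase (Rattus norvegicus); on this read-out higher numbers stand for weaker inhibition and lower numbers for stronger inhibition. In this assay compound 1 gives 14000 nM, and compound 2 gives 26000 nM. Compound 1 holds the smaller of the two numbers, but its gap to compound 2 lies within the scatter, so the two are not told apart. For the measured compounds named here, no step between measured compounds that differ in one place is at hand, so the size of an effect from changing the aryl substituent has not been seen in this set.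

Compound 3 `O=C1NCCN(c2cccc(-c3ccsc3)c2)N1` is not yet measured. It differs from compound 1 by thiophen-3-yl in place of methylsulfanyl on an aromatic carbon. The shared core and the six-membered aromatic ring of carbon only stay the same; only the substituent on that aromatic carbon changes.

Going by the values given here, with no measured step to lean on, the expectation rests on compound 1 at 14000 nM and on the change itself. A step of moderate size toward stronger inhibition is expected, a 2.8-fold lower number from compound 1 to compound 3 (0.45 log units; beyond the scatter). For compound 3 the estimate in this assay is 5000 nM, with a range from 1500 nM to 20000 nM.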

Compound 3, half-maximal inhibitory concentration: 4900 nM
The estimate for compound 3 lay 1.0-fold (0.01 log units) above the measured number, and the stated range covers the measured number.
By their numbers in this assay, from the lowest: compound 3; then compounds 1 and 2 (each within the scatter of the next).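

In this assay the substituent on this aromatic carbon now has its first measured effect: thiophen-3-yl in place of methylsulfanyl gives a 2.9-fold lower number from compound 1 to compound 3 (0.46 log units; beyond the scatter), a modest step, but one beyond the scatter, which the earlier pair could not provide. The position therefore responds to a change of substituent, and a five-membered aromatic ring is accepted here with a gain rather than a loss, at least for this one pair. Nothing at hand bears on why the number falls, so the step stands as an observation only.

From the compounds shown here alone, it remains open whether the gain belongs to thiophen-3-yl in particular or to any aromatic ring on this carbon, a question that phenyl, furan-3-yl or a simple chain such as ethyl at the same place would help to settle. Also open, going by these compounds, is whether an amine or a carboxylic acid on this carbon would shift the number further, and whether thiophen-3-yl would have a similar effect elsewhere on the six-membered aromatic ring.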